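Replacing one group on a strong inhibitor

A few compounds are considered here, and "the series" means these few. Any claim that something is new, unique, unknown or untested is made for them only; others in the source may bear on it.

- compound 1 `CC(C)(O)c1cc(-c2ccccc2)c2ccc(OCc3cccc(C4(O)CCOCC4)c3)cc2c1` gives 59 nM
- compound 2 `OC1(c2cccc(COc3ccc4c(-c5ccoc5)cc(C5=NCCO5)cc4c3)c2)CCOCC1` gives 3 nM

Both values come from a functional assay for inhibition, with Homo sapiens as the target; a higher number here means a weaker inhibitor, a lower number a stronger inhibitor. Of these two, compound 2 has the lower number, 3 nM, so it is the stronger inhibitor, and the gap lies beyond the scatter. Compound 3 `O=C(c1ccccc1)c1cc(-c2ccoc2)c2ccc(OCc3cccc(C4(O)CCOCC4)c3)cc2c1` differs from compound 2 in one place: a group of 8 heavy atoms (7 carbon, 1 oxygen; one six-membered aromatic ring of carbon only) in place of a group of 5 heavy atoms (3 carbon, 1 nitrogen, 1 oxygen; one five-membered non-aromatic ring with 2 hetero atoms), on an aromatic carbon. Going by the values given here, no measured pair isolates a change at this place, and compounds 1 and 2 differ in more than one place, so any expectation here is loose. Compound 1, which carries a different group at this place, gives 59 nM, so a weaker value is expected for compound 3, though not necessarily one as weak. The expected change is a 6.7-fold higher number from compound 2 to compound 3 (0.82 log units; beyond the scatter), a rise in the number and thus weaker inhibition. For compound 3 the estimated value is 20 nM, with an expected range from 4 nM to 100 nM.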

Compound 3, half-maximal inhibitory concentration: 1 nM
Estimate against measurement, compound 3: 20-fold (1.30 log units) above, and the stated range ends above it.
By their numbers in this assay, from the lowest: compound 3; then compound 2; then compound 1.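

In this assay, putting benzoyl in place of the five-membered non-aromatic ring gives a 3.0-fold lower number from compound 2 to compound 3 (0.48 log units; beyond the scatter). This shows that the aromatic carbon para to a fused ring accepts a group of 8 heavy atoms with no loss of inhibition, and in fact with a modest gain. It also shows that the ring with its nitrogen is not needed for strong inhibition here, since compound 3 lacks it and still gives 1 nM, though no measurement on hand says which feature of the change accounts for the gain.

Going by these compounds, with a single step at this position, it stays open whether the carbonyl or the aromatic ring of benzoyl matters more: an acetyl group keeps only the carbonyl, and a benzyl group keeps only the ring. On these data alone, how an amine or a carboxylic acid would fare at this place is also open.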